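The source may hold more compounds than are shown below. What is called first, only, known or untested is meant among the compounds shown, and "the series" means these compounds.

Compound 1 `CNC(=O)c1ccc(NCc2cncn2Cc2ccc(-c3ccccc3)cc2)cc1-c1ccccc1`: > 1000 nM
Compound 2 `COC(=O)c1ccc(NCc2cncn2Cc2ccc(-c3ccccc3)cc2)cc1-c1ccccc1`: > 1000 nM

In a toxicity assay on NIH3T3 cells (Mus musculus) for cytotoxicity, read by resazurin assay (on this read-out lower numbers stand for an effect already at smaller amounts and higher numbers for an effect only at larger amounts of compound), compound 2 gives > 1000 nM, which is a limit of the assay and not a number. Compound 1 gives > 1000 nM, which is also a limit. The whole record so far is thus (the limit of > 1000 nM in this assay, at which 2 of the 2 values shown sit), and no measured number exists to compare against.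

Compound 3 `c1ccc(-c2ccc(Cn3cncc3CNc3ccc(N4CCCCC4)c(-c4ccccc4)c3)cc2)cc1` keeps the shared core and changes one group: piperidin-1-yl in place of methoxycarbonyl on an aromatic carbon. Piperidin-1-yl stands in place of methoxycarbonyl on an aromatic carbon, ortho to a phenyl group and para to a large group. Going by the values given here, the only measured step, a step that the two limits leave unreadable from compound 1 to compound 2, concerns the group that now leaves, but it has no readable size to carry over. Among the compounds with values here, no measured step therefore argues for a change beyond the scatter in this assay, in either direction, and another limit is the likeliest report. The expected step is a step that the limit leaves unreadable from compound 2 to compound 3, and it is an estimate with wide margins. For compound 3 the expected value is 1500 nM, with an estimated range from 400 nM to 5000 nM.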

Compound 3, half-maximal effective concentration: > 1000 nM
Compound 3 was reported as a limit; the forecaster's own chance of this, stated with the estimate: 65%; the middle value does not contradict the limit.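

Going by these compounds alone, no step among compound 1, compound 2 and compound 3 can be read in this assay, and the record remains a single limit rather than a number: the limit of > 1000 nM in this assay, at which 3 of the 3 values shown sit. The compounds shown leave open what value any of the three would reach in this assay, and whether methylcarbamoyl, methoxycarbonyl and piperidin-1-yl differ there at all.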